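This account rests on a few compounds, and the source may have more. Where it says the series, first, only, none or still open, it means among the compounds named here.

Three compounds have been measured in an assay on isolated protein for inhibition of DNA topoisomerase 1 (Homo sapiens), with a stated time of 15 min; on this read-out lower numbers stand for stronger inhibition and higher numbers for weaker inhibition:

Compound 1, `COc1c(N2CC[C@@H](N)C2)c(F)cc2c(=O)c(C(=O)O)cn(Cc3ccc(-c4ccccc4)cc3)c12`, gives 92200 nM.
Compound 2, `CNCCNc1c(F)cc2c(=O)c(C(=O)O)cn(Cc3ccc(-c4ccccc4)cc3)c2c1OC`, gives > 200000 nM.
Compound 3, `CNC[C@@H]1CCN(c2c(F)cc3c(=O)c(C(=O)O)cn(Cc4ccc(-c5ccccc5)cc4)c3c2OC)C1`, gives 155000 nM.

The figure for compound 2 is a limit of the assay, not a number. Among the two plain numbers, compound 3 has the higher one, and the step between these two is a 1.7-fold higher number from compound 1 to compound 3 (0.23 log units; within the scatter). The compound not yet measured is compound 4, `CNCCCCNc1c(F)cc2c(=O)c(C(=O)O)cn(Cc3ccc(-c4ccccc4)cc3)c2c1OC`. It differs from compound 3 in one place: (4-(methylamino)butyl)amino in place of 3-((methylamino)methyl)pyrrolidin-1-yl on an aromatic carbon. Within the data shown here, the one measured step that touches the same kind of change, a ring exchanged for an open chain on that aromatic carbon, is an at least 1.2-fold lower number from compound 2 to compound 3 (0.11 log units; that floor lies within the scatter), and the chain of compound 2 reached only the limit (the limit of > 200000 nM in this assay, at which 1 of the 3 values shown sits). Opening the ring into a longer chain is therefore expected to give a number no lower than that of compound 3, and possibly beyond the limit. For compound 4 the expected step is a 1.3-fold higher number from compound 3 to compound 4 (0.11 log units; within the scatter). Compound 4 is estimated at 200000 nM, with a range from 90000 nM to 450000 nM.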

Compound 4, half-maximal inhibitory concentration: > 200000 nM
Compound 4: a limit, no number (the forecaster's own chance of this, stated with the estimate: 50%); the middle value sits exactly at the limit.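

In this assay compound 4 gives > 200000 nM, a limit and not a number. With the longer (4-(methylamino)butyl)amino chain, the open chains on this aromatic carbon in compound 2 and compound 4 both end at the limit, so the added chain length brings no readable number: the limit of > 200000 nM in this assay, at which 2 of the 4 values shown sit. Against the ring-bearing substituents, this chain gives an at least 2.1-fold higher number from compound 1 to compound 4 (0.33 log units; beyond the scatter), but only an at least 1.2-fold higher number from compound 3 to compound 4 (0.11 log units; that floor lies within the scatter), so a clear separation holds only against the 3-aminopyrrolidin-1-yl group.

The step between the two open-chain compounds cannot be read, so any effect of chain length on this read-out stays hidden. Also open, from the compounds shown here alone, is whether a piperazine ring on this aromatic carbon would give a number lower than those of the pyrrolidine compounds.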